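One side-chain swap on compound 3

The source may hold more compounds than are shown below. What is called first, only, known or untested is meant among the compounds shown, and "the series" means these compounds.

Compound 1 `CCCC(=O)NCCC(=O)c1cc(OC)ccc1N`: 7.35% in an assay for inhibition of Nitric oxide synthase, inducible (Homo sapiens), read by scintillation counting, with a stated time of 30 min, tested at 1 mM; on this read-out lower numbers stand for less inhibition and higher numbers for more inhibition at the one concentration tested (going by the name of the read-out)
Compound 2 `Nc1ccc(Cl)cc1C(=O)CCNC(=O)C1CC1`: 5.37% in this assay
Compound 3 `CCNC(=S)NCCC(O)c1ccccc1N`: 19.4% in this assay

Among these three, compound 3 gives the highest number, and its steps to compound 1 and to compound 2 both lie beyond the scatter, so its inhibition in this assay is the highest of the three measured. Compound 4 `CCCNC(=O)NCCC(O)c1ccccc1N` has not yet been measured. It differs from compound 3 in one place: a group of 6 heavy atoms (4 carbon, 1 nitrogen, 1 oxygen; no ring) in place of a group of 5 heavy atoms (3 carbon, 1 nitrogen, 1 sulfur; no ring), on an amine nitrogen. Going by the values given here, no measured pair differs in only one place, so there is no measured step of this kind to lean on. For an exchange of this size on a side chain, the expected step is none beyond the scatter, or at most a modest drop, in a number 5.4 percentage points lower from compound 3 to compound 4 (within the scatter). Compound 4 is therefore estimated at 14% in this assay, within a range from 3% to 28%.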

Compound 4, a percentage reported as inhibition, at one concentration (the size of the read-out at that concentration, not a potency): 19%
Estimate against measurement, compound 4: 5 percentage points below; low and high end bracket the measured number.
By their numbers in this assay, from the lowest: compounds 2 and 1 (each within the scatter of the next); then compounds 4 and 3 (each within the scatter of the next).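

Going by these compounds alone, the first measured step at this position, with propylcarbamoyl on the amine nitrogen in place of the group of 5 heavy atoms, gives a number 0.4 percentage points lower from compound 3 to compound 4 (within the scatter) in this assay. At this one concentration, the read-out therefore does not separate the two groups, even though sulfur gives way to oxygen and one carbon is added. No measurement here explains this result.

As far as these compounds go, because both changes come in a single exchange, their separate contributions remain unknown. From the compounds shown here alone, whether a longer chain, a ring or a carboxylic acid on this nitrogen would move the number also stays open.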